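The source may report more compounds than this note shows. Statements on the series, on what has been measured and on what is new or still open speak of the compounds shown alone.

Measured compounds:
compound 1 `COCCOC1CCN(c2nc(N)c3cc(OC)c(OC)cc3n2)CC1` with 2.12 nM in an assay on brain for displacement of a labelled ligand from Adrenergic receptor alpha-1 (Rattus norvegicus); on this read-out lower numbers stand for stronger inhibition and higher numbers for weaker inhibition
compound 2 `CCOC(C)COC1CCN(c2nc(N)c3cc(OC)c(OC)cc3n2)CC1` with 0.99 nM
compound 3 `CCOC(COC1CCN(c2nc(N)c3cc(OC)c(OC)cc3n2)CC1)c1ccccc1` with 0.52 nM

Compound 1 stands highest of the three numbers; its nearest neighbour is compound 2 and the furthest is compound 3. Compound 4 `CCOC(C)(COC1CCN(c2nc(N)c3cc(OC)c(OC)cc3n2)CC1)c1ccccc1` has not been measured. It differs from compound 1 as follows: 1-ethoxy-1-phenylethyl in place of methoxymethyl on a saturated chain carbon bound to an oxygen on a saturated carbon.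

Within the data shown here, two measured steps bear on this change. Building out the chain from methoxymethyl to 1-ethoxyethyl gave a 2.1-fold lower number from compound 1 to compound 2 (0.33 log units; beyond the scatter), and to ethoxy(phenyl)methyl gave a 4.1-fold lower number from compound 1 to compound 3 (0.61 log units; beyond the scatter). Between these two, a 1.9-fold lower number from compound 2 to compound 3 (0.28 log units; within the scatter), so the replacement of methyl by phenyl on that carbon did not separate clearly. Among the measured compounds shown here, compound 4 carries both the methyl and the phenyl on the carbon bearing the ethoxy group, so it lies beyond compound 3 in the same direction of growth; no measured pair tests a carbon bearing both groups, so the outcome is taken from the two steps out of compound 1 only.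

For compound 4 the expected result is a step of a 3.5-fold lower number from compound 1 to compound 4 (0.55 log units; beyond the scatter), a modest move in the direction seen across this series. The number expected for compound 4 is 0.6 nM, with a plausible range from 0.2 nM to 1.8 nM.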

Compound 4, inhibition constant: 0.15 nM
Compound 4: middle estimate off by 4.0-fold (0.60 log units), on the high side; the measured number lies below the stated range.
By their numbers in this assay, from the lowest: compound 4; then compounds 3 and 2 (each within the scatter of the next); then compound 1.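

At this position in this assay, the methyl and the phenyl together do what the change between them did not: methyl in place of hydrogen gives a 3.5-fold lower number from compound 3 to compound 4 (0.54 log units; beyond the scatter), and phenyl in place of hydrogen gives a 6.6-fold lower number from compound 2 to compound 4 (0.82 log units; beyond the scatter), both beyond the scatter, whereas a 1.9-fold lower number from compound 2 to compound 3 (0.28 log units; within the scatter) stayed within it. Among these compounds, with 1-ethoxy-1-phenylethyl in place of methoxymethyl, the full change gives a 14-fold lower number from compound 1 to compound 4 (1.15 log units; beyond the scatter), the only large step, and compound 4 now has the lowest number, with its steps to the three other compounds all printed as beyond the scatter. Nothing shown accounts for this gain from carrying both groups on one saturated chain carbon.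

Still open, as far as these compounds go, is whether an ethyl group in place of the methyl, a pyridine ring in place of the phenyl, or a hydroxyl in place of the ethoxy would keep the number this low. Also open is whether the order of these compounds holds in any read-out other than this assay, and how the separate mirror-image forms of compound 4 compare.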